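Adding a methoxy group to the benzyl urea of compound 1

The source may report more compounds than this note shows. Statements on the series, on what has been measured and on what is new or still open speak of the compounds shown alone.

Measured compounds:
compound 1 `CN(C)CCN(C)c1cc(-c2cn[nH]c2)ccc1NC(=O)NCc1ccccc1`, 8.5 nM
compound 2 `O=C(NCc1cccc(Cl)c1)Nc1ccc(-c2cn[nH]c2)cc1`, 17 nM; 17 nM (2 entries)
compound 3 `COc1cccc(CNC(=O)Nc2ccc(-c3ccncc3)cc2)c1`, 5 nM; 5 nM (2 entries)

Going by the values given here, in an assay on isolated protein for inhibition of Rho-associated protein kinase 2 (Homo sapiens), read by HTRF, with a stated time of 4 h (on this read-out lower numbers stand for stronger inhibition and higher numbers for weaker inhibition), compound 1 gives 8.5 nM, the only number it has; two further entries for compound 1 give no single number. Among the compounds with values here, compound 2 gives 17 nM; 17 nM (2 entries) and compound 3 gives 5 nM; 5 nM (2 entries) in this assay, but no step between any of these three is worked out, so only their separate values can be read.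

Compound 4 `COc1cccc(CNC(=O)Nc2ccc(-c3cn[nH]c3)cc2N(C)CCN(C)C)c1` is not yet measured. It differs from compound 1 in one place: methoxy in place of hydrogen on an aromatic carbon. Compound 3 also carries a 3-methoxybenzyl group, though it differs from compound 1 in other parts, so it offers only a loose hint.

Within the data shown here, no measured step covers this change. The expectation is that the step from compound 1 to compound 4, a 1.2-fold lower number from compound 1 to compound 4 (0.08 log units; within the scatter), stays within the usual scatter of this assay, in either direction. Compound 4 is therefore estimated at 7 nM in this assay, with a range from 3 nM to 18 nM.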

Compound 4, half-maximal inhibitory concentration: < 1 nM
Compound 4: a limit, no number (the forecaster's own chance of this, stated with the estimate: 5%); middle value at least 7.0-fold (0.84 log units) away from the limit.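

Going by these compounds alone, this is the first change in one place that can be read, and it shows that the benzyl ring of the urea does not tolerate just anything silently. Replacing one hydrogen on that ring with methoxy, which turns benzyl into 3-methoxybenzyl, gives in this assay an at least 8.5-fold lower number from compound 1 to compound 4 (0.92 log units; beyond the scatter). The value of compound 4, < 1 nM, is a limit of the assay and not a number: the limit of < 1 nM in this assay, at which 1 of the 4 values shown sits.

The compounds shown leave open how much stronger compound 4 really is, since only a lower bound on the step can be read, and they give no reason for the change. They also leave open whether methoxy itself matters, which a hydroxyl, an ethoxy group or an amine at this place on the ring could begin to answer.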